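Lengthening the Chain of Compound 1

The compounds below may be only part of what the source reports. "The series", "measured", "known", "first", "only" and "open" are said of these compounds alone.

In a functional assay on SW480 cells (Homo sapiens) for antiproliferative activity, read by MTT assay, with a stated time of 48 h (on this read-out lower numbers stand for stronger inhibition and higher numbers for weaker inhibition), compound 1 (`CCC(CCO)n1cnc2c(Cl)nc(F)nc21`) gives 19800 nM. For the measured compounds named here, this is the higher of the only two true numbers available, because compound 3 (`CCCCCC(CCO)n1cnc2c(Cl)nc(Cl)nc21`) gives 6010 nM. That gap lies beyond the usual scatter. Compound 2 (`CCC(CCO)n1cnc2c(Cl)ncnc21`) is reported as > 50000 nM, which is a limit of the assay and not a number.

Compound 4 (`CCCCCCCCC(CCO)n1cnc2c(Cl)nc(F)nc21`) keeps the core of compound 1 and alters only the chain: hexyl in place of hydrogen on a saturated chain carbon, three bonds along the chain from an aromatic nitrogen. Going by the values given here, the one measured step, an at least 2.5-fold higher number from compound 1 to compound 2 (0.40 log units; beyond the scatter), swaps fluoro for hydrogen on an aromatic carbon. It therefore shows that this part of the molecule matters in this assay, but it says nothing directly about the chain.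

The only hint on chain length is that compound 1 has a shorter chain than compound 3, and compound 3 gives the lower number at 6010 nM. This hint is weak, since compound 3 also carries chloro where compound 1 carries fluoro, and the two changes cannot be separated. A moderate move towards a lower number is therefore expected, and the estimated step is a 5.0-fold lower number from compound 1 to compound 4 (0.69 log units; beyond the scatter). For compound 4 the expected value is 4000 nM, with an estimated range of 1200 nM to 15000 nM.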

Compound 4, half-maximal inhibitory concentration: 15000 nM
Estimate against measurement, compound 4: 3.8-fold (0.57 log units) below; the range from low to high includes it.
By their numbers in this assay, from the lowest: compound 3; then compounds 4 and 1 (each within the scatter of the next). At a limit, above all of these: compound 2.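

For the compounds shown here, the earlier compounds gave only one step, an at least 2.5-fold higher number from compound 1 to compound 2 (0.40 log units; beyond the scatter), and it concerned an aromatic carbon, so it revealed nothing about the chain. In this assay, going by these compounds alone, placing hexyl on a saturated chain carbon, three bonds along the chain from an aromatic nitrogen, gives the first direct reading at this position: a 1.3-fold lower number from compound 1 to compound 4 (0.12 log units; within the scatter). On this read-out, the two compounds cannot be told apart, so a chain carrying this added hexyl is tolerated here but brings no measurable gain, and nothing available explains why this change leaves the number within the scatter.

The compounds shown give no reading for a chain longer than this one, such as decyl, or for an amine, a carboxylic acid or a phenyl ring at the same position, so it remains unknown whether any other group here would move the number beyond the scatter. Going by these compounds, it also remains open whether hexyl would behave the same way with chloro or hydrogen in place of fluoro on the aromatic carbon, since the chain has so far been read directly only on the core of compound 1.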